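The compounds below may be only part of what the source reports. "The series", "measured", "known", "first", "only" and "open" are said of these compounds alone.

In a functional assay on MCF7 cells (Homo sapiens) for inhibition, read by sulforhodamine B assay, with a stated time of 48 h (on this read-out lower numbers stand for stronger inhibition of growth and higher numbers for weaker inhibition of growth), compound 1 `COC(=O)c1sc2cc(C#Cc3ccccc3F)cnc2c1N` gives only a limit of the assay, > 150000 nM. Compound 2 `COC(=O)c1sc2cc(C#Cc3ccccc3)cnc2c1N` likewise gives a limit, > 150000 nM. The step that the two limits leave unreadable from compound 1 to compound 2 cannot be read, since both values sit at the limit of > 150000 nM in this assay, at which 2 of the 2 values shown sit. Compound 3 `COC(=O)c1sc2cc(C#Cc3ccccn3)cnc2c1N` differs from compound 2 by pyridin-2-yl in place of phenyl on a triple-bonded carbon. No measured step bears on this change; the only step shown, from compound 1 to compound 2, is unreadable, so no direction beyond the scatter is expected. The expected step is therefore a step that the limit leaves unreadable from compound 2 to compound 3. Compound 3 is estimated at 200000 nM, within 80000 nM to 500000 nM, most likely again reported as a limit.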

Compound 3, concentration for 50% growth inhibition: 37400 nM
For compound 3 the middle estimate is 5.3-fold (0.73 log units) above the measured one; the measured number lies below the stated range.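

In this assay, pyridin-2-yl on the triple-bonded carbon gives an at least 4.0-fold lower number from compound 2 to compound 3 (0.60 log units; beyond the scatter), and in place of 2-fluorophenyl it gives an at least 4.0-fold lower number from compound 1 to compound 3 (0.60 log units; beyond the scatter). This position therefore responds to a change of the aromatic ring, which compound 1 and compound 2 could not show, as the step between them cannot be read. Both new steps give only a minimum size, as their starting values are limits: the limit of > 150000 nM in this assay, at which 2 of the 3 values shown sit.

Open, going by these compounds, is how pyridin-3-yl, pyridin-4-yl or a ring bearing an amine would read on the same triple-bonded carbon. On these data alone, the true size of the steps also remains open.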